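A few compounds are considered here, and "the series" means these few. Any claim that something is new, unique, unknown or untested is made for them only; others in the source may bear on it.

Of the compounds shown here, three have been measured in an ADME assay on a cell-free system (plasma, Mus musculus) for protein binding, read by LC-MS, with a stated time of 4 h, tested at 10 uM. Compound 2 (`O=[N+]([O-])c1ccc(C2=NOC(c3ccc(N4CCCCC4)cc3)C2)o1`) gives 98.8%, the highest binding of the three and so the smallest unbound fraction, and its distance from the other two lies beyond the scatter. Compound 1 (`O=C1COCCN1c1ccc(C2CC(c3ccc([N+](=O)[O-])o3)=NO2)cn1`) gives 58.9%, and compound 3 (`CN1CCN(c2ccc(C3CC(c4ccc([N+](=O)[O-])o4)=NO3)cn2)C(=O)C1`) gives 59.8%.

Compound 4 (`O=C1COCCN1c1ccc(C2CC(c3ccc([N+](=O)[O-])o3)=NO2)cc1`) is compound 2 with one change: 3-oxomorpholin-4-yl in place of piperidin-1-yl on an aromatic carbon. In words, 3-oxomorpholin-4-yl stands in place of piperidin-1-yl on an aromatic carbon, para to a large group.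

Going by the values given here, no measured step covers this exchange. Among the compounds with values here, the only step available, a 1.0-fold lower unbound fraction from compound 1 to compound 3 (0.01 log units; within the scatter), stays within the scatter and gives no size for leaving piperidin-1-yl. Within the data shown here, the closest guide is compound 1, which already carries 3-oxomorpholin-4-yl and gives 58.9%, although its aromatic ring is not the one found in compound 4. A large move towards more free compound therefore seems likely, though probably not the whole distance to that value. The expected change is a 21-fold higher unbound fraction from compound 2 to compound 4 (1.32 log units; beyond the scatter), an estimated rise in the unbound fraction beyond the scatter in this assay. For compound 4 the estimated value is 75%, with an expected range from 58% to 90%.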

Compound 4, plasma protein binding: 66%
Beside the measured number, compound 4's estimate is 1.4-fold (0.13 log units) (unbound fraction) below it; the range from low to high includes it.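

The exchange of piperidin-1-yl for 3-oxomorpholin-4-yl on an aromatic carbon, para to a large group, gives a 28-fold higher unbound fraction from compound 2 to compound 4 (1.45 log units; beyond the scatter) in this assay, so the first size for this change is now available, and it is large. Going by these compounds alone, a single group at this place on a six-membered aromatic ring of carbon only can therefore shift plasma protein binding strongly, whereas the only earlier step, a 1.0-fold lower unbound fraction from compound 1 to compound 3 (0.01 log units; within the scatter), showed no shift beyond the scatter when one neutral ring gave way to another on the other aromatic ring. Nothing measured here accounts for the size of this step.

The compounds shown leave open whether the step depends on the ring oxygen, on the carbonyl or on both, and morpholin-4-yl or piperidin-2-one-1-yl at the same place would separate those parts of the exchange. They also leave open how an amine such as dimethylamino or a carboxylic acid at this place would compare, and whether piperidin-1-yl on the aromatic ring of compound 1 would give a step of similar size.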